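This account rests on a few compounds, and the source may have more. Where it says the series, first, only, none or still open, it means among the compounds named here.

Measured compounds:
compound 1 `COc1nccc(NCc2ccc(CNc3ccnc(OC)n3)cc2)n1`: 10 nM
compound 2 `Fc1ccc(NCc2ccc(CNc3ccc(F)cn3)cc2)nc1`: 100 nM

Of the compounds shown here, two built on the same core have been measured in an assay on MDA-MB-231 cells for displacement of a labelled ligand from C-X-C chemokine receptor type 4 (Homo sapiens); a lower number here means that less compound is needed, a higher number that more compound is needed for the effect. Compound 1 gives 10 nM in this assay, and compound 2 gives 100 nM. Of the two numbers, that of compound 2 is the higher, and the gap to compound 1 lies beyond the scatter of the measurement. For the measured compounds named here, compound 1 carries the same group on both amine nitrogens, while compound 2 carries two groups of another kind; no single-change step between them can be drawn.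

Compound 3 `Fc1ccc(NCc2ccc(CNc3ncccn3)cc2)nc1` has not yet been measured in this assay. It differs from compound 2 in one place: pyrimidin-2-yl in place of 5-fluoropyridin-2-yl on an amine nitrogen. Only one of the two amine nitrogens is altered. Since the two measured compounds differ in more than one place, the size of this change alone cannot be read from them. Compound 3 is expected to give a number somewhat lower than compound 2, a step of a 1.7-fold lower number from compound 2 to compound 3 (0.22 log units; within the scatter), possibly still within the scatter. The estimate for compound 3 is 60 nM, with a range from 20 nM to 200 nM.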

Compound 3, effective concentration (reported as EC, without a stated level of effect): 1 nM
The estimate for compound 3 lay 60-fold (1.78 log units) above the measured number; measured number below the stated range.
By their numbers in this assay, from the lowest: compound 3; then compound 1; then compound 2.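

In this assay the exchange of 5-fluoropyridin-2-yl for pyrimidin-2-yl on an amine nitrogen gives a 100-fold lower number from compound 2 to compound 3 (2.00 log units; beyond the scatter) and so counts as a large change. Because only one of the two amine nitrogens is altered while the other keeps its 5-fluoropyridin-2-yl group, the result shows that the group on a single amine nitrogen can by itself move the number well beyond the scatter, something the two earlier compounds could not show. No measurement shown here accounts for the size of this step.

The change removes the fluorine and adds a second ring nitrogen at once, so the compounds shown do not separate the two, and an unsubstituted pyridin-2-yl group on the same nitrogen would be needed to tell them apart. For the compounds shown here, compound 1 differs from compound 3 in more than one place, so no step between them can be read, and it remains open how pyrimidin-2-yl would behave on both amine nitrogens.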